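A few compounds are considered here, and "the series" means these few. Any claim that something is new, unique, unknown or untested is made for them only; others in the source may bear on it.

Compound 1 `Cc1cc(C)c(CN2CCc3c(Cl)cc([C@@H](CO)[C@@H]4CCCO4)c(Cl)c3C2=O)c(=O)[nH]1` is measured in an assay for inhibition of histone-lysine N-methyltransferase EZH2 variant Y641N (Homo sapiens), read by scintillation counting, with a stated time of 60 min, in the presence of a further agent that is not named here (on this read-out higher numbers stand for weaker inhibition and lower numbers for stronger inhibition), where compound 1 gives 135 nM. Compound 3 `COc1cc(C)[nH]c(=O)c1CN1CCc2c(Cl)cc([C@@H](O)C3COC3)c(Cl)c2C1=O` gives 1500 nM in this assay, a higher number that lies beyond the scatter, so compound 1 holds the lowest of the two single numbers. Compound 2 `COC(c1cc(Cl)c2c(c1Cl)C(=O)N(Cc1c(C)cc(C)[nH]c1=O)CC2)C1CCN(C2COC2)CC1` gives 530 nM; 0.64 nM (2 entries) in this assay; its several entries the several entries of compound 2 in this assay, 530 nM; 0.64 nM (2 entries) do not agree with one another and give no single number. Compound 4 `Cc1cc(C)c(CN2CCc3c(Cl)cc([C@H](C)CO)c(Cl)c3C2=O)c(=O)[nH]1` has not yet been measured. It differs from compound 1 by methyl in place of oxolan-2-yl on a saturated chain carbon bound to an aromatic carbon and a saturated chain carbon. Among the measured compounds shown here, no step between measured compounds shows the effect of this change. Compound 4 is expected to give a modestly higher number in this assay, a step of a 3.0-fold higher number from compound 1 to compound 4 (0.47 log units; beyond the scatter), with an estimated 400 nM and a range from 150 nM to 1200 nM.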

Compound 4, inhibition constant: 17 nM
The estimate for compound 4 lay 24-fold (1.37 log units) above the measured number; measured number below the stated range.
By their numbers in this assay, from the lowest: compound 4; then compound 1; then compound 3.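

In this assay, the oxolan-2-yl on this saturated chain carbon proves dispensable: methyl in its place gives a 7.9-fold lower number from compound 1 to compound 4 (0.90 log units; beyond the scatter), so the smaller group goes with the stronger inhibition. Among the compounds shown here, no earlier pair of compounds gave any reading of a change at this place. Nothing measured here accounts for the size of this step.

Going by these compounds, only these two groups are compared at this carbon, so it stays open whether methyl itself matters or merely the loss of the ring. On these data alone, how an ethyl group, a longer chain or an amine would fare at this place also remains unknown.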